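The compounds below may be only part of what the source reports. "The series", "measured", "known", "first", "only" and "open" are said of these compounds alone.

Two members of the series have been run in a functional assay on Hep 3B2 cells (Homo sapiens) for antiproliferative activity, read by MTT assay, with a stated time of 24 h, tested at 0.01 ug/mL; a higher number here means a stronger effect of the compound at the concentration tested, a lower number a weaker effect. Compound 1 `CCOc1ccc2nc(C(=O)Nc3c(F)cc(-c4cccc(F)c4)cc3F)c(C)c(O)c2c1` gives -0.5% in this assay. Compound 2 `Cc1c(C(=O)Nc2ccc(-c3ccccc3)cc2)nc2ccccc2c1O` gives 0.23% in this assay. The two values lie within the scatter of each other, so compound 2 cannot be set apart from compound 1 on these numbers; both sit close to zero, which at this concentration amounts to no measurable effect for either compound.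

Compound 3 `Cc1c(C(=O)Nc2ccc(-c3ccccc3)cc2)nc2ccccc2c1C(=O)O` has not yet been measured in this assay. Its relation to compound 2 is a single change, (carboxy in place of hydroxy on an aromatic carbon), with the rest of the structure kept as it is. For the measured compounds named here, no pair of measured compounds differs in one place, so there is no measured step to lean on for this change. With both measured compounds near zero in this assay, the step from compound 2 to compound 3 is expected to be none beyond the scatter, a number 0.3 percentage points higher from compound 2 to compound 3 (within the scatter). Compound 3 is therefore estimated at 0.5% in this assay, with a range from -8% to 10%.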

Compound 3, a percentage reported as inhibition, at one concentration (the size of the read-out at that concentration, not a potency): -0.68%
Estimate against measurement, compound 3: 1.2 percentage points above; the range from low to high includes it.
By their numbers in this assay, from the lowest: compounds 3, 1 and 2 (each within the scatter of the next).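

In this assay, for the compounds shown here, the first one-place step, carboxy in place of hydroxy on the aromatic carbon opposite the ring nitrogen, comes out as a number 0.9 percentage points lower from compound 2 to compound 3 (within the scatter) and so gives the series its first direct reading at this position. Compound 2 and compound 3 both stay close to zero at this one concentration, so the step does not separate the two groups, and neither group stands out on this read-out. No measured evidence on either group bears on this result.

The compounds shown leave open whether any other group on this aromatic carbon, such as an amine, a methoxy group or a longer chain, would give a number clearly apart from zero in this assay. Also open, on these data alone, is whether hydroxy and carboxy at this position would differ at a higher concentration, where a read-out well above zero would give a step room to show beyond the scatter.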